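Side chain of the series: dimethylamino to methoxy

The source may report more compounds than this note shows. Statements on the series, on what has been measured and on what is new or still open speak of the compounds shown alone.

Values in a functional assay on LNCaP cells (Homo sapiens) for antiproliferative activity; a higher number here means a weaker inhibitor, a lower number a stronger inhibitor:
- compound 1 `Cn1ncc(Cl)c1-c1cc(C(=O)N[C@@H]2CN[C@H](CC(O)CO)C[C@H]2c2ccc(Cl)c(Cl)c2)oc1Cl` gives 70 nM
- compound 2 `Cn1ncc(Cl)c1-c1cc(C(=O)N[C@@H]2CN[C@H](CC(N)=O)C[C@H]2c2ccc(Cl)c(Cl)c2)oc1Cl` gives 160 nM
- compound 3 `CN(C)CC[C@@H]1C[C@@H](c2ccc(Cl)c(Cl)c2)[C@H](NC(=O)c2cc(-c3c(Cl)cnn3C)c(Cl)o2)CN1` gives 1930 nM

Compound 3 carries the highest number of the three. The gaps to it are large: a 12-fold higher number from compound 2 to compound 3 (1.08 log units; beyond the scatter) and a 28-fold higher number from compound 1 to compound 3 (1.44 log units; beyond the scatter). The next structure, compound 4 `COCC[C@@H]1C[C@@H](c2ccc(Cl)c(Cl)c2)[C@H](NC(=O)c2cc(-c3c(Cl)cnn3C)c(Cl)o2)CN1`, has not been measured. It differs from compound 3 as follows: methoxy in place of dimethylamino on a saturated chain carbon, two bonds along the chain from a saturated ring carbon. In words, this is methoxy in place of dimethylamino on a saturated chain carbon, two bonds along the chain from a saturated ring carbon.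

Within the data shown here, no measured step makes this exact exchange, and methoxy itself is untested here. The closest evidence comes from the changes on the same side chain. Among the measured compounds shown here, compound 3 is the only measured compound with dimethylamino, and the two compounds without it differ only modestly: a 2.3-fold higher number from compound 1 to compound 2 (0.36 log units; beyond the scatter). Compound 4 also lacks dimethylamino, so it is expected to sit nearer compound 2, at 160 nM, than compound 3 does. For the measured compounds named here, with only three measured compounds, this expectation stays loose in this assay.

The expected step is a 7.7-fold lower number from compound 3 to compound 4 (0.89 log units; beyond the scatter), a large one towards a lower number. For compound 4 the estimated value is 250 nM, with an expected range of 80 nM to 800 nM.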

Compound 4, half-maximal inhibitory concentration: 250 nM
Estimate against measurement, compound 4: no gap at the digits printed, and the stated range covers the measured number.
By their numbers in this assay, from the lowest: compound 1; then compounds 2 and 4 (each within the scatter of the next); then compound 3.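

In this assay, among these compounds, methoxy in place of dimethylamino gives a 7.7-fold lower number from compound 3 to compound 4 (0.89 log units; beyond the scatter) on a chain of otherwise unchanged length, which is the first direct reading of this exchange, on a saturated chain carbon, two bonds along the chain from a saturated ring carbon. Methoxymethyl in place of carbamoyl gives a 1.6-fold higher number from compound 2 to compound 4 (0.19 log units; within the scatter) in the same assay, so these two side chains are not told apart here, and compound 3 remains the only compound of the four far out at the high end. Methoxymethyl in place of 1,2-dihydroxyethyl gives a 3.6-fold higher number from compound 1 to compound 4 (0.55 log units; beyond the scatter) as a further step, which leaves compound 1 with the lowest number of the four and shows that the side chain still matters once dimethylamino is gone.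

The compounds shown leave open whether the high number of compound 3 belongs to dimethylamino alone or also to a primary amine or a morpholine on this chain, and whether a carboxylic acid or a longer chain ending in methoxy would read like compound 4. The data shown give no measured explanation for any of these steps.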